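A few compounds are considered here, and "the series" means these few. Any claim that something is new, unique, unknown or untested is made for them only; others in the source may bear on it.

Compound 1 `N#Cc1c(N)nc(SCc2ncn[nH]2)c(C#N)c1-c1ccc(OCC2CC2)cc1`, in an assay on CHO cells for displacement of a labelled ligand from adenosine receptor A3 (Homo sapiens), read by scintillation counting, with a stated time of 120 min, tested at 1 uM (on this read-out lower numbers stand for less inhibition and higher numbers for more inhibition at the one concentration tested (going by the name of the read-out)), compound 1 gives 1%.
Compound 2 `N#Cc1c(N)nc(SCc2nc3ccccc3[nH]2)c(C#N)c1-c1ccc(OCC2CC2)cc1`, in this assay compound 2 gives 1%.
Compound 3 `CNC(=O)CSc1nc(N)c(C#N)c(-c2ccc(OCC3CC3)cc2)c1C#N`, in this assay compound 3 gives 3%.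

The three compounds share one core and differ only in the group carried on a saturated chain carbon bound to a sulfur. Going from compound 1 to compound 2 that group changes from 1H-1,2,4-triazol-5-yl to 1H-benzimidazol-2-yl, and the result is no change at the digits printed from compound 1 to compound 2 (within the scatter). Replacing the triazole with methylcarbamoyl gives a number 2 percentage points higher from compound 1 to compound 3 (within the scatter), and the benzimidazole to methylcarbamoyl step gives a number 2 percentage points higher from compound 2 to compound 3 (within the scatter). Compound 3 thus holds the largest of the three numbers, but each step to it lies within the scatter, so the three compounds cannot be told apart in this assay.

Compound 4 `N#Cc1c(N)nc(SCC(=O)NO)c(C#N)c1-c1ccc(OCC2CC2)cc1` is the next step from compound 3: hydroxy in place of methyl on an amide-type nitrogen. Among the measured compounds shown here, no measured pair changes this same amide nitrogen, so the closest guidance is that three quite different groups on the chain carbon all gave near-zero numbers. Because of a number 2 percentage points higher from compound 1 to compound 3 (within the scatter) and a number 2 percentage points higher from compound 2 to compound 3 (within the scatter), compound 4 is expected to show no step beyond the scatter, no change at the digits printed from compound 3 to compound 4 (within the scatter). The estimate for compound 4 in this assay is 3%, between -6% and 14%.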

Compound 4, a percentage reported as inhibition, at one concentration (the size of the read-out at that concentration, not a potency): 31%
Compound 4: middle estimate off by 28 percentage points, on the low side; measured number outside the range, above it.
By their numbers in this assay, from the lowest: compounds 1, 2 and 3 (each within the scatter of the next); then compound 4.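

In this assay, among the compounds shown here, hydroxy in place of methyl on an amide-type nitrogen gives a number 28 percentage points higher from compound 3 to compound 4 (beyond the scatter) and is the first change here to rise beyond the scatter, so this group is not indifferent to what it carries: exchanging one heavy atom is enough to register. The hydroxycarbamoyl group also separates from both ring groups on the saturated chain carbon bound to a sulfur, with a number 30 percentage points higher from compound 2 to compound 4 (beyond the scatter) and with a number 30 percentage points higher from compound 1 to compound 4 (beyond the scatter) even though those two ring groups and methylcarbamoyl could not be told apart. Nothing measured here accounts for this rise.

As far as these compounds go, it remains open whether the hydroxy itself is required, and methoxy on the same amide-type nitrogen, an unsubstituted amide or a carboxylic acid in place of hydroxycarbamoyl would help to separate these possibilities. The number for compound 4 also comes from a single concentration and is not a potency, so its strength against this receptor remains undefined.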